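The source may report more compounds than this note shows. Statements on the series, on what has been measured and on what is new or still open speak of the compounds shown alone.

- Compound 1 `CC(C)c1cc2c3c(c1OC(=O)CCl)OC(=O)[C@@]31CCCC(C)(C)[C@@H]1CC2`: 130000 nM
- Compound 2 `CC(C)C(=O)Oc1c(C(C)C)cc2c3c1OC(=O)[C@@]31CCCC(C)(C)[C@@H]1CC2`: 119000 nM

In an ADME assay on MRC5 cells (Homo sapiens) for cytotoxicity, read by neutral red uptake, with a stated time of 24 h (a higher number here means a weaker inhibitor, a lower number a stronger inhibitor), compound 1 gives 130000 nM. Among the compounds with values here, only one other compound has been measured, and the two cannot be told apart: the step is a 1.1-fold lower number from compound 1 to compound 2 (0.04 log units; within the scatter). That step put isopropyl in place of chloromethyl on a carbonyl carbon.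

Compound 3 `CC(C)c1cc2c3c(c1OC(=O)c1cccnc1)OC(=O)[C@@]31CCCC(C)(C)[C@@H]1CC2` keeps the shared core and changes the same spot: pyridin-3-yl in place of chloromethyl on a carbonyl carbon. In words, pyridin-3-yl takes the place of chloromethyl on a carbonyl carbon. Within the data shown here, the entering group brings a six-membered aromatic ring, and no measured step has tested a ring here, so the evidence is thin. Among the measured compounds shown here, with a 1.1-fold lower number from compound 1 to compound 2 (0.04 log units; within the scatter) as the only guide, no step beyond the scatter is expected in this assay. The expected step is a 1.3-fold lower number from compound 1 to compound 3 (0.11 log units; within the scatter). For compound 3 the estimated value is 100000 nM, with an expected range from 40000 nM to 200000 nM.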

Compound 3, half-maximal inhibitory concentration: 296000 nM
Compound 3: the middle estimate sits 3.0-fold (0.47 log units) below what was measured; measured number above the stated range.
By their numbers in this assay, from the lowest: compounds 2 and 1 (each within the scatter of the next); then compound 3.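

The group on the carbonyl carbon can move the number in this assay: pyridin-3-yl gives a 2.3-fold higher number from compound 1 to compound 3 (0.36 log units; beyond the scatter) and also a 2.5-fold higher number from compound 2 to compound 3 (0.40 log units; beyond the scatter), both modest steps. This makes compound 3 the weakest inhibitor of the three, whereas chloromethyl and isopropyl could not be told apart. Pyridin-3-yl is also the only one of the three groups with a ring or a nitrogen, so this single compound cannot show which of these features goes with the higher number, and no supporting measurement explains the step.

On these data alone, it remains open whether phenyl, which has the ring without the nitrogen, would give a similar number. As far as these compounds go, it is also open whether a longer chain, an amine or a carboxylic acid at this place would shift the number further.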